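The source may hold more compounds than are shown below. What is called first, only, known or untested is meant among the compounds shown, and "the series" means these compounds.

Working notes on the series. Compound 1 `N#C[C@@H]1CCCN1C(=O)[C@@H]1C[C@H](C(=O)N2CCOCC2)CN1` gives 73% in an assay on the whole organism (plasma, strain Sprague-Dawley) for inhibition of Dipeptidyl peptidase 4 (Rattus norvegicus), with a stated time of 6 h, at a dose of 1 mg/kg by the oral route (a lower number here means less inhibition, a higher number more inhibition at the dose given (going by the name of the read-out)), the second highest of the three numbers measured. Compound 2 `CN(C)C(=O)C[C@@H]1CN[C@H](C(=O)N2CCC[C@H]2C#N)C1` gives 66%, a number within the scatter of compound 1. Within the data shown here, compound 3 `N#C[C@@H]1CCCN1C(=O)[C@@H]1C[C@H](C(=O)N2CCCCC2)CN1` gives 84%; the step of a number 11 percentage points higher from compound 1 to compound 3 (beyond the scatter) is the only measured step. Compound 4 `CN(C)C(=O)[C@@H]1CN[C@H](C(=O)N2CCC[C@H]2C#N)C1` differs from compound 1 by dimethylamino in place of morpholin-4-yl on a carbonyl carbon. Among the measured compounds shown here, no measured step exchanges morpholin-4-yl for dimethylamino on this carbonyl carbon; the only step at that carbon, a number 11 percentage points higher from compound 1 to compound 3 (beyond the scatter), went up, while the other compound carrying a dimethylamino, compound 2, sits at 66%. The expected step of a number 3 percentage points lower from compound 1 to compound 4 (within the scatter) is therefore small, not beyond the scatter. Compound 4 is estimated at 70%, with a range from 55% to 82%.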

Compound 4, a percentage reported as inhibition, in the whole organism at one dose (the size of the read-out at that dose, not a potency): 76%
Estimate against measurement, compound 4: 6 percentage points below; measured number inside the range.
By their numbers in this assay, from the lowest: compounds 2, 1, 4 and 3 (each within the scatter of the next, the first and the last beyond it).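

In this assay, dimethylamino on a carbonyl carbon, which has no ring, stays within the scatter of both ring-bearing amides: a number 3 percentage points higher from compound 1 to compound 4 (within the scatter) and a number 8 percentage points lower from compound 3 to compound 4 (within the scatter). Replacing (dimethylcarbamoyl)methyl with dimethylcarbamoyl on a saturated ring carbon also stays within the scatter, with a number 10 percentage points higher from compound 2 to compound 4 (within the scatter). No measurement available here explains these steps. As far as these compounds go, what pyrrolidin-1-yl or diethylamino would give on this carbonyl carbon remains open. These single-dose readings also leave the relative potency of the compounds open.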